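Chiral urea enantiomer pair, whole-organism read-out

A few compounds are considered here, and "the series" means these few. Any claim that something is new, unique, unknown or untested is made for them only; others in the source may bear on it.

Measured so far:
compound 1 `C[C@H](NC(=O)Nc1ccccc1Cl)c1ccccc1` 104%
compound 2 `C[C@H](NC(=O)Nc1cccc(Cl)c1)c1ccccc1` 99%
compound 3 `C[C@@H](NC(=O)Nc1cccc(Cl)c1Cl)c1ccccc1` 100%

In an ADME assay on the whole organism with Oryza sativa as the target, tested at 1 uM (on this read-out lower numbers stand for a stronger effect and higher numbers for a weaker effect at the one concentration tested), compound 3 gives 100%. Compound 2 gives 99% and compound 1 gives 104%; the gaps from compound 3 to each of them lie within the scatter, so the three numbers cannot be told apart. Compound 4 `C[C@H](NC(=O)Nc1cccc(Cl)c1Cl)c1ccccc1` has not yet been measured. Against compound 3 the change is: the two compounds have the same atoms and bonds and differ only in configuration as drawn: 1 of 1 stereo elements differ; a stereocentre at a saturated chain carbon is drawn R in compound 3 and S in compound 4. Going by the values given here, no pair of measured compounds differs in configuration alone, so there is no measured step to set the size of this one. Since every number in the set so far sits within the scatter of every other, the step from compound 3 to compound 4 is expected to stay within the scatter: no change at the digits printed from compound 3 to compound 4 (within the scatter). Compound 4 is therefore estimated at 100%, range 90% to 110%.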

Compound 4, a percentage reported as activity, at one concentration (the size of the read-out at that concentration, not a potency): 100%
Compound 4: middle estimate and measured number agree at the digits printed; low and high end bracket the measured number.
By their numbers in this assay, from the lowest: compounds 2, 3, 4 and 1 (each within the scatter of the next).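

In this assay, the pair separated by configuration alone reads no change at the digits printed from compound 3 to compound 4 (within the scatter), so at this stereocentre the drawn configuration gives no difference that can be read: the fact that compounds 3 and 4 differ only in the configuration as drawn. Chloro in place of hydrogen on an aromatic carbon also stays inside the scatter, reading a number 1 percentage points higher from compound 2 to compound 4 (within the scatter) and a number 4 percentage points lower from compound 1 to compound 4 (within the scatter). No compound shown separates from the others on this read-out.

On these data alone, whether any structural change can move the read-out beyond the scatter stays open. As far as these compounds go, the effect of an amine, a carboxylic acid or a longer chain on the shared core in this assay also stays open.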